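Fluoro to methoxy on compound 2

A few compounds are considered here, and "the series" means these few. Any claim that something is new, unique, unknown or untested is made for them only; others in the source may bear on it.

Compound 1 `COc1ccc2[nH]c(-c3cn(-c4ccccc4)nc3-c3ccc(F)cc3)nc2c1`: 7510 nM
Compound 2 `Fc1ccc(-c2nn(-c3ccccc3)cc2-c2nc3cc(C(F)(F)F)ccc3[nH]2)cc1`: 3520 nM

Both compounds were tested in a functional assay on HeLa cells (Homo sapiens) for antiproliferative activity, read by MTT assay, with a stated time of 48 h; on this read-out lower numbers stand for stronger inhibition and higher numbers for weaker inhibition. Compound 2, at 3520 nM, holds the lower of the two numbers. For the measured compounds named here, the only measured step is a 2.1-fold lower number from compound 1 to compound 2 (0.33 log units; beyond the scatter), a modest one, with trifluoromethyl in place of methoxy on an aromatic carbon.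

Compound 3 `COc1ccc(-c2nn(-c3ccccc3)cc2-c2nc3cc(C(F)(F)F)ccc3[nH]2)cc1` has not yet been measured. It differs from compound 2 by methoxy in place of fluoro on an aromatic carbon, para to a large group, so that 4-fluorophenyl becomes 4-methoxyphenyl.

Going by the values given here, no measured step changes this group itself. The step of a 2.1-fold lower number from compound 1 to compound 2 (0.33 log units; beyond the scatter) involves methoxy at a different place, so it offers only a weak hint of a slightly higher number for the methoxy compound. No step beyond the scatter is therefore expected in this assay, and any drift is expected to be upward. The expected change is a 1.3-fold higher number from compound 2 to compound 3 (0.11 log units; within the scatter). For compound 3 the estimated value is 4500 nM, with an expected range from 1700 nM to 12000 nM.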

Compound 3, half-maximal inhibitory concentration: 2760 nM
Estimate against measurement, compound 3: 1.6-fold (0.21 log units) above, within the range that was stated.
By their numbers in this assay, from the lowest: compounds 3 and 2 (each within the scatter of the next); then compound 1.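

In this assay, for the compounds shown here, methoxy in place of fluoro on an aromatic carbon, para to a large group, is the first change measured at this position, and it gives a step within the scatter (a 1.3-fold lower number from compound 2 to compound 3 (0.11 log units; within the scatter)), so 4-fluorophenyl and 4-methoxyphenyl cannot be told apart on this read-out. The earlier step, at a different place, involved another exchange and lay beyond the scatter (a 2.1-fold lower number from compound 1 to compound 2 (0.33 log units; beyond the scatter)), so the hint it offered about methoxy does not carry over to this position, where the larger methoxy group, with its added hydrogen-bond acceptor by the count, produces no readable change. No evidence on any property of these compounds bears on this result, which therefore stands as an observation without an explanation.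

The compounds shown leave open whether this position would also accept an amine, a carboxylic acid or a longer chain such as butoxy without a step beyond the scatter, since fluoro and methoxy are the only two groups seen there. They also leave open whether methoxy at this position would behave in the same way with methoxy in place of trifluoromethyl on the other part of the molecule.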